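Methylation of a phenol on a diterpenoid flavonol conjugate

The source may report more compounds than this note shows. Statements on the series, on what has been measured and on what is new or still open speak of the compounds shown alone.

Measured so far:
compound 1 `CC(=O)c1c(O)cc(O)cc1OC/C=C(\C)CC/C=C(\C)CCC=C(C)C`, 32000 nM
compound 2 `C=C1CC[C@H]2C(C)(C)CCC[C@]2(C)[C@H]1CC/C(C)=C/Cc1c(O)cc2oc(-c3ccc(O)cc3)c(O)c(=O)c2c1O`, > 100000 nM
compound 3 `C=C1CC[C@H]2C(C)(C)CCC[C@]2(C)[C@H]1CC/C(C)=C/COc1cc(O)c2c(=O)c(O)c(-c3ccc(O)cc3)oc2c1`, > 100000 nM

All three compounds were tested in a functional assay on A549 cells (Homo sapiens) for cytotoxicity, read by XTT assay, with a stated time of 72 h; on this read-out lower numbers stand for stronger inhibition and higher numbers for weaker inhibition. Among the compounds with values here, compound 1 is the only one to give a number, at 32000 nM. For compound 2 the result is a limit of the assay, > 100000 nM, not a number. Compound 3 likewise gives only a limit, > 100000 nM, so its true position is not pinned down beyond that. the limit of > 100000 nM in this assay, at which 2 of the 3 values shown sit, shows how two of the three results stand at the same limit. Within the data shown here, no pair of measured compounds differs in one place, so no measured step is available.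

Compound 4 `C=C1CC[C@H]2C(C)(C)CCC[C@]2(C)[C@H]1CC/C(C)=C/COc1cc(O)c2c(=O)c(O)c(-c3ccc(OC)cc3)oc2c1` is the next compound. It differs from compound 3 by methyl in place of hydrogen on an oxygen on an aromatic ring; the same difference, cut one bond further out, reads hydroxy to methoxy, and 4-hydroxyphenyl to 4-methoxyphenyl. With compound 3 sitting at the limit, no step beyond the scatter can be read from the numbers, and the expected step from compound 3 to compound 4 in this assay is a step that the limit leaves unreadable from compound 3 to compound 4. Compound 4 is therefore expected to give 150000 nM, within a range from 50000 nM to 500000 nM, most probably again as a limit rather than a number.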

Compound 4, half-maximal inhibitory concentration: > 100000 nM
Compound 4: only a limit was reported (the forecaster's own chance of this, stated with the estimate: 80%); the middle value is on the limit's open side.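

Compound 3 and compound 4 both stand at a limit of the assay and not at a number, so swapping hydrogen for methyl on an oxygen on an aromatic ring gives no step that can be read: the limit of > 100000 nM in this assay, at which 3 of the 4 values shown sit.

Going by these compounds, whether 4-hydroxyphenyl and 4-methoxyphenyl differ at all in their effect on these cells stays open: neither compound gives a number to compare.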